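Amide aryl swap on a naphthyridine-pyrazole scaffold

The source may report more compounds than this note shows. Statements on the series, on what has been measured and on what is new or still open speak of the compounds shown alone.

The series is followed in a functional assay on HeLa cells (Homo sapiens) for antiproliferative activity, read by MTT assay, with a stated time of 48 h (a lower number here means a stronger inhibitor, a higher number a weaker inhibitor), where two compounds have been measured. Compound 1, `Cn1cc(-c2cnc3ccnc(N)c3c2)cn1`, gives 40800 nM in this assay. Compound 2, `CC(=O)Nc1ccc2ncc(-c3cnn(C)c3)cc2n1`, carries an acetamide in place of the free amine, and in this assay compound 2 reaches only the limit of > 50000 nM, not a measured number. Of the two values shown, one sits at the limit of > 50000 nM in this assay, at which 1 of the 2 values shown sits, so compound 2 stands at the weak end of what this assay can report, with no number of its own. Compound 3, `Cn1cc(-c2cnc3ccc(NC(=O)c4ccc(F)cc4)nc3c2)cn1`, keeps the acetamide-type linkage of compound 2 but changes what hangs on the carbonyl: 4-fluorophenyl in place of methyl on a carbonyl carbon. For the measured compounds named here, no measured pair in this set shows the effect of such a change, so the size of the step rests on expectation alone. The author expects a gain beyond the scatter, with the step from compound 2 to compound 3 estimated at an at least 2.5-fold lower number from compound 2 to compound 3 (0.39 log units; beyond the scatter) in this assay. Compound 3 is therefore estimated at 20000 nM, within a range of 3000 nM to 50000 nM in this assay.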

Compound 3, half-maximal inhibitory concentration: > 50000 nM
Compound 3: a limit, no number; the forecaster's own chance of this, stated with the estimate: 35%; middle value at least 2.5-fold (0.39 log units) from the limit.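

In this assay compound 3 gives > 50000 nM, a limit and not a number. For the compounds shown here, compound 2 also stands at a limit, so no step between compound 2 and compound 3 can be read: the limit of > 50000 nM in this assay, at which 2 of the 3 values shown sit. The compounds shown leave open whether 4-fluorophenyl in place of methyl on a carbonyl carbon changes the activity at all.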